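This account rests on a few compounds, and the source may have more. Where it says the series, first, only, none or still open, it means among the compounds named here.

Among the measured compounds shown here, compound 2 `CCCN(c1nc(C)nc2c(-c3c(C)cc(OC)cc3OC)c(C)nn12)C1CC1` is one of two compounds measured in an assay on cell membranes for displacement of a labelled ligand from corticotropin-releasing factor receptor 1 (Rattus norvegicus) (a higher number here means a weaker inhibitor, a lower number a stronger inhibitor), where compound 2 gives 1.48 nM. The other, compound 1 `CCN(CCC#N)c1nc(C)nc2c(-c3c(C)cc(OC)cc3OC)c(C)nn12`, gives 2.48 nM in this assay; the two numbers sit within the scatter of each other. Compound 3 `CCCCN(CC)c1nc(C)nc2c(-c3c(C)cc(OC)cc3OC)c(C)nn12` differs from compound 2 in one place: butyl(ethyl)amino in place of cyclopropyl(propyl)amino on an aromatic carbon. For the measured compounds named here, the only step measured so far changes the same amino group, a 1.7-fold lower number from compound 1 to compound 2 (0.22 log units; within the scatter), and stays within the scatter. A similar outcome is therefore expected here, with no step beyond the scatter in this assay. Compound 3 is estimated at 2 nM, with a range from 0.8 nM to 5 nM, a step of a 1.4-fold higher number from compound 2 to compound 3 (0.13 log units; within the scatter) that is expected to lie within the scatter.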

Compound 3, half-maximal inhibitory concentration: 1.72 nM
The estimate for compound 3 lay 1.2-fold (0.07 log units) above the measured number, within the range that was stated.
By their numbers in this assay, from the lowest: compounds 2, 3 and 1 (each within the scatter of the next).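

In this assay, the three-membered carbon ring of cyclopropyl(propyl)amino gives way to the open chains of butyl(ethyl)amino with no step beyond the scatter (a 1.2-fold higher number from compound 2 to compound 3 (0.07 log units; within the scatter)). On the chain, ethyl in place of the nitrile also stays within the scatter (a 1.4-fold lower number from compound 1 to compound 3 (0.16 log units; within the scatter)), so this position accepts both all-carbon amino groups and the nitrile-bearing one. No supporting evidence accounts for this result. The compounds shown leave open how a hydroxyl, a carboxylic acid or a second amine on the chain would read in this assay. As far as these compounds go, a much longer chain also remains open.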